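Adding a Methylpiperazine to the Urea Phenyl

This account rests on a few compounds, and the source may have more. Where it says the series, first, only, none or still open, it means among the compounds named here.

Compound 3 `O=C(Nc1ccccc1)Nc1ccc2ncnc(Nc3cccc(C(F)(F)F)c3)c2c1` carries an unsubstituted phenyl on the urea of the shared core. In a functional assay on A-431 cells (Homo sapiens) for antiproliferative activity, read by MTT assay, with a stated time of 72 h (on this read-out lower numbers stand for stronger inhibition and higher numbers for weaker inhibition), compound 3 gives > 10000 nM, which is a limit of the assay rather than a number. Two measured analogues show what a substituent on that phenyl does. Compound 1 `O=C(Nc1ccc(CN2CCCC2)cc1)Nc1ccc2ncnc(Nc3cccc(C(F)(F)F)c3)c2c1` gives 1360 nM in this assay, and compound 2 `O=C(Nc1cccc(CN2CCCCC2)c1)Nc1ccc2ncnc(Nc3cccc(C(F)(F)F)c3)c2c1` gives 1330 nM. The step of an at least 7.3-fold higher number from compound 1 to compound 3 (0.86 log units; beyond the scatter) and the step of an at least 7.5-fold higher number from compound 2 to compound 3 (0.87 log units; beyond the scatter) both run the same way, each ending at the limit of > 10000 nM in this assay, at which 1 of the 3 values shown sits.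

The step now under consideration, from compound 3 to compound 4 `CN1CCN(c2ccc(NC(=O)Nc3ccc4ncnc(Nc5cccc(C(F)(F)F)c5)c4c3)cc2)CC1`, is 4-methylpiperazin-1-yl in place of hydrogen on an aromatic carbon. It resembles a reversal of those two steps: a nitrogen-containing saturated ring is again placed on the phenyl of the urea, though here the ring is attached directly to the aromatic carbon rather than through a methylene. On that basis compound 4 is expected to sit well below the limit reached by compound 3, with an improvement of about an at least 6.6-fold lower number from compound 3 to compound 4 (0.82 log units; beyond the scatter) in this assay. Compound 4 is therefore estimated at 1500 nM, with a plausible range from 400 nM to 6000 nM.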

Compound 4, half-maximal inhibitory concentration: 2200 nM
Compound 4: middle estimate off by 1.5-fold (0.17 log units), on the low side, within the range that was stated.
By their numbers in this assay, from the lowest: compounds 2, 1 and 4 (each within the scatter of the next). At a limit, above all of these: compound 3.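

In this assay, the change gives an at least 4.5-fold lower number from compound 3 to compound 4 (0.65 log units; beyond the scatter), which shows that the saturated nitrogen ring need not be held on a methylene: 4-methylpiperazin-1-yl set directly on the aromatic carbon, para to a large group, also brings the number down from the limit. Set against the (pyrrolidin-1-yl)methyl group of compound 1, the same group gives a 1.6-fold higher number from compound 1 to compound 4 (0.21 log units; within the scatter), so these two substituents cannot be told apart on this read-out, although one has the ring attached directly and the other through a methylene. The gain over compound 3 can be read only as a bound, because the value of compound 3 is a limit: the limit of > 10000 nM in this assay, at which 1 of the 4 values shown sits.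

On these data alone, what a morpholin-4-yl or a cyclohexyl group would give on the same carbon stays open, and with it whether a ring nitrogen is needed at all. Also open, as far as these compounds go, is whether 4-methylpiperazin-1-yl would give a similar number on the phenyl carbon that carries (piperidin-1-yl)methyl in compound 2, and what an open-chain dimethylamino group would give in place of the ring.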